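The compounds below may be only part of what the source reports. "The series", "measured", "known", "first", "only" and "open" are said of these compounds alone.

Measured in an ADME assay on MDCK cells (Canis lupus familiaris) for cytotoxicity, read by microscopy, with a stated time of 48 h; a lower number here means that less compound is tolerated, a higher number that more compound is tolerated:

Compound 1, `CCCc1csc(CN[C@@H]2C[C@H]3C[C@@H]([C@H]2C)C3(C)C)c1`: 12500 nM
Compound 2, `C[C@H]1[C@H](NCc2cncnc2)C[C@H]2C[C@@H]1C2(C)C`: > 100000 nM
Compound 3, `C[C@H]1[C@H](NCc2sccc2-c2ccccc2)C[C@H]2C[C@@H]1C2(C)C`: 12500 nM

Compound 2 gives no number in this assay; its value is a limit of the assay, (the limit of > 100000 nM in this assay, at which 1 of the 3 values shown sits). Compound 1 and compound 3 each give a number in this assay, and their two values lie within the usual scatter of each other.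

Compound 4, `C[C@H]1[C@H](NCc2ccco2)C[C@H]2C[C@@H]1C2(C)C`, differs from compound 2 by furan-2-yl in place of pyrimidin-5-yl on a saturated chain carbon bound to an amine nitrogen. For the measured compounds named here, no step between measured compounds mirrors this change, so the expectation rests on the three values alone. For compound 4 the expected step is an at least 2.5-fold lower number from compound 2 to compound 4 (0.39 log units; beyond the scatter), downwards, and by more than the scatter. The estimate for compound 4 in this assay is 40000 nM, expected to fall between 12500 nM and 100000 nM.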

Compound 4, minimum cytotoxic concentration: 50000 nM
Compound 4: middle estimate off by 1.3-fold (0.10 log units), on the low side; low and high end bracket the measured number.
By their numbers in this assay, from the lowest: compounds 1 and 3 (each within the scatter of the next); then compound 4. At a limit, above all of these: compound 2.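

Furan-2-yl in place of pyrimidin-5-yl on a saturated chain carbon bound to an amine nitrogen gives, in this assay, an at least 2.0-fold lower number from compound 2 to compound 4 (0.30 log units; that floor lies within the scatter). This is the only pair shown that differs in one place, and it gives the position its one readable step. Compound 2 stands at a limit of the assay, so only a floor for the step is known: the limit of > 100000 nM in this assay, at which 1 of the 4 values shown sits.

This one pair cannot separate the ring size from the hetero atoms. From the compounds shown here alone, how a pyridine ring or a carboxylic acid would read at this position remains open.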